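Swapping the Aryl Amide for a Sulfonamide

A few compounds are considered here, and "the series" means these few. Any claim that something is new, unique, unknown or untested is made for them only; others in the source may bear on it.

Measured compounds in a functional assay on MIA PaCa-2 cells (Homo sapiens) for inhibition, read by MTT assay, with a stated time of 7 days; a lower number here means a stronger inhibitor, a higher number a weaker inhibitor:
compound 1 `CCN(CC)S(=O)(=O)c1ccc(S(=O)(=O)N2CCC[C@@H](C(=O)N3CCS(=O)(=O)CC3)C2)cc1`: 900 nM
compound 2 `CCN(CC)C(=O)c1ccc(S(=O)(=O)N2CCC[C@@H](C(=O)N3CCC(F)(F)CC3)C2)cc1`: 70 nM
compound 3 `CCN(CC)S(=O)(=O)c1ccc(S(=O)(=O)N2CCC[C@@H](C(=O)N3CCC(COC)CC3)C2)cc1`: 250 nM

Compound 2 stands lowest of the three numbers, with compound 3 nearest and compound 1 furthest. Going by the values given here, the one single-point step measured so far is a 3.6-fold lower number from compound 1 to compound 3 (0.56 log units; beyond the scatter), which concerns the group on the carbonyl carbon and not the aromatic substituent. Compound 2 and compound 3 differ in two places at once, so their two values only show that compound 2 sits lower than compound 3; how much of that gap belongs to the aromatic substituent cannot be separated.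

Compound 4 `CC(C)NS(=O)(=O)c1ccc(S(=O)(=O)N2CCC[C@@H](C(=O)N3CCC(F)(F)CC3)C2)cc1` carries the change (isopropylsulfamoyl in place of diethylcarbamoyl on an aromatic carbon). Among the compounds with values here, no measured step addresses this exchange alone, so the expected direction rests on compound 1 and compound 3, which both bear a sulfamoyl group and give higher numbers than compound 2; a modestly higher number than compound 2 is therefore expected, with wide uncertainty. Compound 4 is estimated at 160 nM, within 50 nM to 500 nM, corresponding to the expected step of a 2.3-fold higher number from compound 2 to compound 4 (0.36 log units; beyond the scatter).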

Compound 4, half-maximal inhibitory concentration: 350 nM
Beside the measured number, compound 4's estimate is 2.2-fold (0.34 log units) below it, within the range that was stated.
By their numbers in this assay, from the lowest: compound 2; then compounds 3 and 4 (each within the scatter of the next); then compound 1.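

Going by these compounds alone, exchanging diethylcarbamoyl for isopropylsulfamoyl on the aromatic carbon gives in this assay a 5.0-fold higher number from compound 2 to compound 4 (0.70 log units; beyond the scatter) and is the first step in which this substituent changes while the group on the carbonyl carbon stays the same. The aromatic position therefore responds to this exchange on its own, and the earlier gap between compound 2 and compound 3 could not show this. No measured evidence here bears on the reason for this step.

On these data alone, the exchange alters both the linking group and the alkyl groups on nitrogen, so the share of each remains open. Isopropylcarbamoyl, or diethylsulfamoyl with the group on the carbonyl carbon of compound 2, would separate them, and how a carboxylic acid at this position would compare also stays unknown.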